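This account rests on a few compounds, and the source may have more. Where it says the series, first, only, none or still open, it means among the compounds named here.

Of the compounds shown here, three of one family have been tested in a functional assay on MCF7 cells (Homo sapiens) for inhibition, read by MTT assay, with a stated time of 72 h; on this read-out lower numbers stand for stronger inhibition and higher numbers for weaker inhibition. Compound 3 `CN(C(=O)NC(=O)c1ccc(F)c(F)c1)c1nc(C(F)(F)F)c(C(=O)N/N=C/c2cccc(C(F)(F)F)c2)s1` gives 4.15 ug/mL in this assay, and compound 1 `CN(C(=O)NC(=O)c1ccc(F)c(F)c1)c1nc(C(F)(F)F)c(C(=O)N/N=C/c2ccccc2C(F)(F)F)s1` gives 8.21 ug/mL. Between them lies a single change, (2-(trifluoromethyl)phenyl in place of 3-(trifluoromethyl)phenyl on a carbon with a double bond to nitrogen), and the measured step is a 2.0-fold higher number from compound 3 to compound 1 (0.30 log units; within the scatter), so the two numbers cannot be told apart with confidence.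

Compound 2 `Cc1nc(N(C)C(=O)NC(=O)c2c(F)cccc2F)sc1C(=O)N/N=C/c1cccc(C(F)(F)F)c1` belongs to a second core. How this core differs from the core of compound 3 is not broken down here. In this assay compound 2 gives 28.2 ug/mL, which is the highest of the three numbers, beyond the scatter from both compound 1 and compound 3.

Compound 4 `Cc1nc(N(C)C(=O)NC(=O)c2c(F)cccc2F)sc1C(=O)N/N=C/c1ccccc1C(F)(F)F` has not yet been measured in this assay. It stands to compound 2 as compound 1 stands to compound 3: the change is 2-(trifluoromethyl)phenyl in place of 3-(trifluoromethyl)phenyl on a carbon with a double bond to nitrogen, the same change made once before. Since that earlier change moved the number only within the scatter, as a 2.0-fold higher number from compound 3 to compound 1 (0.30 log units; within the scatter) shows, the expected step from compound 2 to compound 4 is likewise small, a 1.4-fold higher number from compound 2 to compound 4 (0.15 log units; within the scatter). On that basis compound 4 is expected to give about 40 ug/mL, most plausibly between 15 ug/mL and 110 ug/mL.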

Compound 4, half-maximal inhibitory concentration: 7.34 ug/mL
For compound 4 the middle estimate is 5.4-fold (0.74 log units) above the measured one; the measured number lies below the stated range.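

On the core of compound 2, 2-(trifluoromethyl)phenyl in place of 3-(trifluoromethyl)phenyl gives a 3.8-fold lower number from compound 2 to compound 4 (0.58 log units; beyond the scatter) in this assay, a real gain in inhibition on this core. The effect of this change therefore does not carry over unchanged from one core to the other: the same change on two cores in this assay, a 2.0-fold higher number (0.30 log units; within the scatter) from compound 3 to compound 1 and a 3.8-fold lower number (0.58 log units; beyond the scatter) from compound 2 to compound 4, 7.6-fold (0.88 log units) apart, beyond the scatter of two such steps This shows that, for these two pairs, what the change does depends on the core it is made on, but it does not show which feature of the cores is responsible, and two pairs give no rule for predicting a further core.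

The compounds shown also leave open which part of the cores matters, as the two cores differ in more than one place. From the compounds shown here alone, it also remains open whether another group on the phenyl ring in place of trifluoromethyl, such as a nitrile, a methoxy group or an amine, would depend on the core in the same way.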